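The source may hold more compounds than are shown below. What is called first, only, known or untested is meant among the compounds shown, and "the series" means these compounds.

Of the compounds shown here, two have values so far in a functional assay on A549 cells (Homo sapiens) for antiproliferative activity, read by MTT assay, with a stated time of 48 h; a lower number here means a stronger inhibitor, a higher number a weaker inhibitor: compound 1 `COc1cc(C(=O)/C=C/c2c[nH]c3ccccc23)cc(SC)c1OC` gives 152 nM and compound 2 `COc1cc(C(=O)/C=C/c2cn(C)c3ccccc23)cc(N)c1OC` gives 498 nM. Compound 2 has the higher number of the two, and its gap to compound 1 lies beyond the scatter. Compound 3 `COc1cc(C(=O)/C=C/c2c[nH]c3ccccc23)cc(N)c1OC` differs from compound 2 by hydrogen in place of methyl on an aromatic nitrogen. Within the data shown here, no measured step isolates this change, and compound 1 also differs from compound 3 elsewhere. A modest move toward a lower number in this assay is therefore expected, perhaps none beyond the scatter. The expected step is a 1.5-fold lower number from compound 2 to compound 3 (0.18 log units; within the scatter). Compound 3 is estimated at 330 nM, with a range of 110 nM to 1000 nM.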

Compound 3, half-maximal inhibitory concentration: 342 nM
For compound 3 the middle estimate is 1.0-fold (0.02 log units) below the measured one, and the stated range covers the measured number.
By their numbers in this assay, from the lowest: compound 1; then compounds 3 and 2 (each within the scatter of the next).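

In this assay, hydrogen and methyl on the aromatic nitrogen are not separated when the amino group is present (a 1.5-fold lower number from compound 2 to compound 3 (0.16 log units; within the scatter)). Among these compounds, with hydrogen on that nitrogen, amino in place of methylsulfanyl on an aromatic carbon gives the only single change beyond the scatter (a 2.3-fold higher number from compound 1 to compound 3 (0.35 log units; beyond the scatter)). No available data bear on the reason for either step.

As far as these compounds go, whether methyl on the nitrogen would give a similar step with methylsulfanyl on the aromatic carbon remains open. Also open, from the compounds shown here alone, is how a longer chain such as ethyl on the nitrogen, or hydroxyl on that carbon, would read.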